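From isobutyl to hydroxy on the aromatic carbon

A few compounds are considered here, and "the series" means these few. Any claim that something is new, unique, unknown or untested is made for them only; others in the source may bear on it.

In a functional assay on KB cells (Homo sapiens) for antiproliferative activity, read by sulforhodamine B assay, with a stated time of 3 days (on this read-out lower numbers stand for an effect already at smaller amounts and higher numbers for an effect only at larger amounts of compound), compound 1 `CCCc1ccc(-c2cc(=O)c3c(o2)C(CC)(CC)C(=O)C(CC)=C3O)cc1` gives > 53 uM, which is a limit of the assay. Compound 2 `CCC1=C(O)c2c(oc(-c3ccc(C(C)C)cc3)cc2=O)C(CC)(CC)C1=O` gives 8.13 uM, and compound 3 `CCC1=C(O)c2c(oc(-c3ccc(CC(C)C)cc3)cc2=O)C(CC)(CC)C1=O` gives 29.3 uM, the higher of these two numbers. Compound 4 `CCC1=C(O)c2c(oc(-c3ccc(O)cc3)cc2=O)C(CC)(CC)C1=O` carries hydroxy in place of isobutyl on an aromatic carbon, para to a large group: hydroxy in place of isobutyl on an aromatic carbon. The nearest measured steps exchange one carbon chain for another at that place: an at least 6.5-fold lower number from compound 1 to compound 2 (0.81 log units; beyond the scatter) and a 3.6-fold higher number from compound 2 to compound 3 (0.56 log units; beyond the scatter). None introduces hydroxy, and they set no direction, so no step beyond the scatter is expected in this assay. For compound 4 the estimated value is 25 uM, with an expected range of 8 uM to 70 uM. This estimate means an expected 1.2-fold lower number from compound 3 to compound 4 (0.07 log units; within the scatter).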

Compound 4, concentration for half-maximal effect: 20.6 uM
The estimate for compound 4 lay 1.2-fold (0.08 log units) above the measured number, within the range that was stated.
By their numbers in this assay, from the lowest: compound 2; then compounds 4 and 3 (each within the scatter of the next). At a limit, above all of these: compound 1.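

In this assay, a hydroxy with a hydrogen-bond donor and acceptor at this place, on an aromatic carbon para to a large group, reads level with the four-carbon isobutyl: a 1.4-fold lower number from compound 3 to compound 4 (0.15 log units; within the scatter). The other two exchanges give a 2.5-fold higher number from compound 2 to compound 4 (0.40 log units; beyond the scatter) and an at least 2.5-fold lower number from compound 1 to compound 4 (0.41 log units; beyond the scatter), so the carbon chains do not all fall on one side of hydroxy. The value of compound 1 is a limit, not a number: the limit of > 53 uM in this assay, at which 1 of the 4 values shown sits.

From the compounds shown here alone, whether an amine, a methoxy or a carboxylic acid here would read with compound 2 or with compounds 3 and 4 stays open. The compounds shown also give no reason why hydroxy and isobutyl read alike.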